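Hydroxy on the amino nitrogen of a bromoindazole

A few compounds are considered here, and "the series" means these few. Any claim that something is new, unique, unknown or untested is made for them only; others in the source may bear on it.

Measured so far:
compound 1, `Oc1cccc(CNc2cc(Br)cc3[nH]ncc23)c1`, 55%
compound 2, `Nc1cccc(CNc2cc(Br)cc3[nH]ncc23)c1`, "not active" (no number reported)

Two compounds share one core and differ only in the group on the pendant benzene ring. In an assay for inhibition of Tryptophan 2,3-dioxygenase (Homo sapiens), with a stated time of 1 h, tested at 10 uM (on this read-out lower numbers stand for less inhibition and higher numbers for more inhibition at the one concentration tested (going by the name of the read-out)), compound 1 gives 55%. Compound 2 carries an amino group where compound 1 carries a hydroxy group, and in this assay compound 2 is reported as "not active" (no number reported), without any number attached, so its place is only that it sits at the bottom of what has been seen here. Compound 3, `ONc1cccc(CNc2cc(Br)cc3[nH]ncc23)c1`, is not yet measured and differs from compound 2 in one place: hydroxy in place of hydrogen on a nitrogen on an aromatic ring. Among the compounds with values here, since compound 2 gave no number, no measured step from it exists. The change puts a hydroxy group onto the nitrogen, and compound 1, which carries a hydroxy group directly on the ring, reached 55%; a modest upward step in this assay from compound 2 is therefore expected, though a result again reported as not active is quite possible. Compound 3 is estimated at 25%, with a range from 0% to 55%.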

Compound 3, a percentage reported as inhibition, at one concentration (the size of the read-out at that concentration, not a potency): "not active" (no number reported)
Compound 3 has no reported number here, and the estimate cannot be compared.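

Within the data shown here, compound 2 gives "not active" (no number reported) and compound 3 gives "not active" (no number reported), so no step between them can be read. Nothing shown here offers an explanation for this result. The compounds shown leave open whether the change from amino to hydroxyamino alters inhibition at all, and by how much.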